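Swapping a Cyclopentyl for Phenyl on a Urea Nitrogen

The source may report more compounds than this note shows. Statements on the series, on what has been measured and on what is new or still open speak of the compounds shown alone.

Measured compounds:
- compound 1 `COc1ccc(-c2c(C)nc(NC(=O)NC3CCCCC3)c(C)c2C(OC(C)(C)C)C(=O)O)cc1`: 19000 nM
- compound 2 `Cc1ccc(-c2c(C)nc(NC(=O)NC3CCCC3)c(C)c2C(OC(C)(C)C)C(=O)O)cc1C`: 8000 nM
- compound 3 `Cc1nc(NC(=O)NC2CCCCC2)c(C)c(C(OC(C)(C)C)C(=O)O)c1-c1ccc2c(c1)CCCO2`: 17000 nM

These three compounds share a core and were tested in an ADME assay on MT4 cells (Homo sapiens) for cytotoxicity, read by MTT assay; on this read-out lower numbers stand for higher toxicity in this test and higher numbers for lower toxicity in this test. Compound 2 gives the lowest of the three numbers, and its gaps to compound 3 and to compound 1 both lie beyond the scatter, so compound 2 is the most toxic of the three in this assay.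

Among the measured compounds shown here, the only step measured between two compounds differing in one place is a 1.1-fold lower number from compound 1 to compound 3 (0.05 log units; within the scatter), which changes the aromatic group on the core and not the urea side. Compound 1 and compound 2 differ in two places at once, so their values alone cannot be split into separate contributions.

Compound 4 `Cc1ccc(-c2c(C)nc(NC(=O)Nc3ccccc3)c(C)c2C(OC(C)(C)C)C(=O)O)cc1C` differs from compound 2 by phenyl in place of cyclopentyl on an amide-type nitrogen. For the measured compounds named here, no measured step touches this position, so nothing in the data points to a direction, and no step beyond the scatter is expected; the estimate for compound 4 is therefore anchored to compound 2 with a broad range. Compound 4 is expected to give 8000 nM in this assay, between 3000 nM and 25000 nM, which means an expected step of no change at the digits printed from compound 2 to compound 4 (within the scatter).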

Compound 4, half-maximal cytotoxic concentration: 9900 nM
The estimate for compound 4 lay 1.2-fold (0.09 log units) below the measured number; the range from low to high includes it.
By their numbers in this assay, from the lowest: compounds 2, 4, 3 and 1 (each within the scatter of the next, the first and the last beyond it).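

Phenyl in place of cyclopentyl on the amide-type nitrogen gives a 1.2-fold higher number from compound 2 to compound 4 (0.09 log units; within the scatter) in this assay and is the first measured step at this position. A five-membered non-aromatic ring of carbon only can thus be exchanged for a six-membered aromatic ring of carbon only on the core of compound 2 without a readable change in this test, so the two compounds cannot be told apart here. Nothing measured here offers an explanation for this result.

From the compounds shown here alone, this single step cannot show how far the tolerance at this nitrogen extends, and it remains open whether an open chain such as n-butyl, or a phenyl carrying an amine or a carboxylic acid, would also stay within the scatter of compound 2. Among the compounds shown here, it also remains open whether phenyl on this nitrogen would give a similar result alongside the other aromatic groups found in compound 1 and compound 3, since the one step here was read only on the core of compound 2.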